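The source may report more compounds than this note shows. Statements on the series, on what has been measured and on what is new or still open speak of the compounds shown alone.

Measured so far in an assay for binding affinity to Melanocortin receptor 4 (Homo sapiens); on this read-out lower numbers stand for stronger inhibition and higher numbers for weaker inhibition:
Compound 1 `CCN(CC)CCCC(C)/N=C(/N)NC(=O)c1cccc(F)c1OCc1cc(Br)ccc1OC` gives 900 nM.
Compound 2 `CCN(CC)CCCC(C)/N=C(/N)NC(=O)c1cccc(F)c1CCc1ccc2ccccc2c1` gives 690 nM.
Compound 3 `CCN(CC)CCCC(C)/N=C(/N)NC(=O)c1cccc(F)c1CCc1cc(Br)ccc1OC` gives 4.3 nM.

Compound 3 stands lowest of the three, with a 210-fold lower number from compound 1 to compound 3 (2.32 log units; beyond the scatter) and a 160-fold lower number from compound 2 to compound 3 (2.21 log units; beyond the scatter), both clearly beyond the scatter. Compound 4 `CCN(CC)CCCC(C)/N=C(/N)NC(=O)c1cccc(F)c1CCc1ccccc1Cl` differs from compound 3 only by 2-chlorophenyl in place of 5-bromo-2-methoxyphenyl on a saturated chain carbon, two bonds along the chain from an aromatic carbon. The step that bears on this is the one in which the 5-bromo-2-methoxyphenyl group entered, a 160-fold lower number from compound 2 to compound 3 (2.21 log units; beyond the scatter): swapping the aryl group at this position moved the number a great deal. Removing the bromine and methoxy group again is therefore expected to cost binding, though how much is uncertain, and the expected step is a 47-fold higher number from compound 3 to compound 4 (1.67 log units; beyond the scatter). Compound 4 is estimated at 200 nM, within 30 nM to 1500 nM.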

Compound 4, inhibition constant: 26000 nM
Beside the measured number, compound 4's estimate is 130-fold (2.11 log units) below it, and the stated range ends below it.
By their numbers in this assay, from the lowest: compound 3; then compounds 2 and 1 (each within the scatter of the next); then compound 4.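

In this assay the aryl group on this chain matters even more than compound 2 and compound 3 suggested: 2-chlorophenyl in place of 5-bromo-2-methoxyphenyl gives a 6000-fold higher number from compound 3 to compound 4 (3.78 log units; beyond the scatter), and in place of naphthalen-2-yl it gives a 38-fold higher number from compound 2 to compound 4 (1.58 log units; beyond the scatter). The change from the larger group of the oxygen-containing analogue gives a 29-fold higher number from compound 1 to compound 4 (1.46 log units; beyond the scatter), leaving compound 4 with the highest number of the four. No measurement here gives a reason for these steps.

Still open, from the compounds shown here alone, is which part of 5-bromo-2-methoxyphenyl carries the low number. A 2-methoxyphenyl group, without the bromine, would help separate the two.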